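Isobutyl in place of hydrogen, compound 2 to compound 3

This account rests on a few compounds, and the source may have more. Where it says the series, first, only, none or still open, it means among the compounds named here.

Among the measured compounds shown here, compound 2 `CC(=O)c1ccc(NC(=O)CN(C(=O)c2ccccc2)S(=O)(=O)c2ccccc2)cc1` stands lowest of the two numbers known so far in a functional assay for inhibition, read by spectrophotometry, with a stated time of 20 min, tested at 5 mg/mL (a lower number here means a weaker effect, a higher number a stronger effect of the compound at the concentration tested), at 45.4%. Compound 1 `CC(=O)c1ccc(NC(=O)C(CC(C)C)N(C(=O)c2ccccc2)S(=O)(=O)c2ccc(C)cc2)cc1` gives 71.3% in this assay. Compound 3 `CC(=O)c1ccc(NC(=O)C(CC(C)C)N(C(=O)c2ccccc2)S(=O)(=O)c2ccccc2)cc1` has not yet been measured; it differs from compound 2 by isobutyl in place of hydrogen on a saturated chain carbon bound to an amide-type nitrogen and a carbonyl carbon. For the measured compounds named here, no step between measured compounds is known. An upward step beyond the scatter is expected, since compound 1 also carries isobutyl and gives 71.3%. Compound 3 is expected to give about 65% in this assay, between 45% and 85%, an estimated upward step of a number 19.6 percentage points higher from compound 2 to compound 3 (beyond the scatter).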

Compound 3, a percentage reported as inhibition, at one concentration (the size of the read-out at that concentration, not a potency): 52.2%
For compound 3 the middle estimate is 12.8 percentage points above the measured one; low and high end bracket the measured number.
By their numbers in this assay, from the lowest: compounds 2 and 3 (each within the scatter of the next); then compound 1.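

In this assay, isobutyl in place of hydrogen on the saturated chain carbon gives a number 6.8 percentage points higher from compound 2 to compound 3 (within the scatter), so this change alone is not shown to move the read-out. Hydrogen in place of methyl on an aromatic carbon gives a number 19.1 percentage points lower from compound 1 to compound 3 (beyond the scatter), a modest step and the only one here beyond the scatter. Nothing on hand bears on a cause for either step.

Open, as far as these compounds go, is whether methyl on that aromatic carbon gives a like step without isobutyl. Also open, from the compounds shown here alone, is how a methoxy group there, or a longer chain in place of isobutyl, would read.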